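The source may report more compounds than this note shows. Statements on the series, on what has been measured and on what is new or still open speak of the compounds shown alone.

Compound 1 `CC(C)C[C@H](NC(=O)OCC1CC2CCC1C2)C(=O)N[C@H](C=O)C[C@H]1CCNC1=O` was examined in a functional assay on Huh-7 cells (Homo sapiens) for cytotoxicity; a higher number here means that more compound is tolerated, a lower number that less compound is tolerated. In that test compound 1 gives only a limit, > 100000 nM, so no single number places it. Compound 2 `CC(C)C[C@H](NC(=O)OCC1CC2C=CCC(C2)C1)C(=O)N[C@@H](C[C@H]1CCNC1=O)C(O)S(=O)(=O)O` likewise gives only limits in this assay, > 100000 nM; > 100000 nM (2 entries). Compound 3 `CC(C)C[C@H](NC(=O)OCC1CC2CCC1C2)C(=O)N[C@@H](C[C@H]1CCNC1=O)C(O)S(=O)(=O)O` has not yet been measured. It differs from compound 1 in one place: hydroxy(sulfo)methyl in place of formyl on a saturated chain carbon bound to an amide-type nitrogen and a saturated chain carbon. Among the compounds with values here, because compound 1 stands at the limit of > 100000 nM in this assay, at which 1 of the 2 values shown sits, no measured step is available, and only a step that the limit leaves unreadable from compound 1 to compound 3 is expected, nothing beyond the scatter. Compound 3 is therefore expected to tolerate about 150000 nM, somewhere between 60000 nM and 400000 nM.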

Compound 3, half-maximal cytotoxic concentration: > 100000 nM
Compound 3 ended at the assay's limit; the forecaster's own chance of this, stated with the estimate: 85%; the middle value is on the limit's open side.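

No step can be read from compound 1 to compound 3, since each gives only a limit: the limit of > 100000 nM in this assay, at which 2 of the 3 values shown sit.

The compounds shown leave open what concentration would harm the cells, and whether hydroxy(sulfo)methyl in place of formyl changes it at all.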